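Piperidinyl to pyrrolidinyl on the amide of compound 2

The compounds below may be only part of what the source reports. "The series", "measured", "known", "first", "only" and "open" are said of these compounds alone.

Compound 2 `CC(C)n1cc(-c2ccnc3[nH]c(C4CCN(CC(=O)N5CCCCC5)CC4)cc23)ccc1=O` gives 159 mL/min/kg in an ADME assay (Rattus norvegicus, strain Han-wistar) for pharmacokinetics, at a dose of 1.5 umol/kg by the intravenous route (on this read-out higher numbers stand for fast clearance and lower numbers for slow clearance), the higher of the two numbers recorded so far. Compound 1 `COc1cc(C(=O)N2CCCC2)ccc1-c1ccnc2[nH]c(C3CCOCC3)cc12` gives 22 mL/min/kg in this assay, and the gap between the two lies beyond the scatter. Compound 3 `CC(C)n1cc(-c2ccnc3[nH]c(C4CCN(CC(=O)N5CCCC5)CC4)cc23)ccc1=O` carries pyrrolidin-1-yl in place of piperidin-1-yl on a carbonyl carbon. Within the data shown here, no step between measured compounds isolates this change, so nothing measured here tells its size. The step expected is a 1.1-fold lower number from compound 2 to compound 3 (0.06 log units; within the scatter), none beyond the scatter. Compound 3 is estimated to give about 140 mL/min/kg in this assay, with a range expected from 75 mL/min/kg to 260 mL/min/kg.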

Compound 3, clearance: 91 mL/min/kg
Compound 3: the middle estimate sits 1.5-fold (0.19 log units) above what was measured, and the stated range covers the measured number.
By their numbers in this assay, from the lowest: compound 1; then compounds 3 and 2 (each within the scatter of the next).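

In this assay, among these compounds, pyrrolidin-1-yl in place of piperidin-1-yl on a carbonyl carbon gives a 1.7-fold lower number from compound 2 to compound 3 (0.24 log units; within the scatter), the first measured step at this position. Removing one ring carbon therefore does not separate these two amides on this read-out. No supporting measurement bears on this result.

Going by these compounds, whether morpholin-4-yl or dimethylamino on the same carbonyl carbon would give a step beyond the scatter remains open. So does whether any such step would hold with a different group on the rest of the scaffold.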